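Quinoxaline-diamine series: sulfanyl linker in place of benzylamino

The source may hold more compounds than are shown below. What is called first, only, known or untested is meant among the compounds shown, and "the series" means these compounds.

Measured so far:
compound 1 `COc1ccc(CNc2nc3cc(N)cc(N)c3nc2-c2ccccc2)cc1OC`, 27500 nM in a functional assay on PC-3 cells (Homo sapiens) for inhibition, read by sulforhodamine B assay, with a stated time of 48 h; a higher number here means a weaker inhibitor of growth, a lower number a stronger inhibitor of growth
compound 2 `Nc1cc(N)c2nc(-c3ccccc3)c(NCc3ccc(F)cc3)nc2c1`, 15500 nM

In this assay, for the measured compounds named here, compound 2 holds the lowest of the two numbers; the only measured step, a 1.8-fold lower number from compound 1 to compound 2 (0.25 log units; within the scatter), is within the scatter. Compound 3 `Nc1cc(N)c2nc(-c3ccccc3)c(Sc3ccc(F)cc3)nc2c1` carries the change ((4-fluorophenyl)sulfanyl in place of (4-fluorobenzyl)amino on an aromatic carbon). Going by the values given here, no measured step bears on this change, since the single step alters the aryl group and not the linker. The expected step is therefore a 1.3-fold higher number from compound 2 to compound 3 (0.11 log units; within the scatter), none beyond the scatter, with a wide range. Compound 3 is estimated at 20000 nM, between 6000 nM and 70000 nM.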

Compound 3, concentration for total growth inhibition: < 100000 nM
Compound 3 ended at the assay's limit; the forecaster's own chance of this, stated with the estimate: 15%; the middle value lies beyond the limit too.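

In this assay compound 3 gives < 100000 nM, a limit of the assay and not a number. The step from compound 2 to compound 3 cannot be read. The compounds shown leave open how (4-fluorophenyl)sulfanyl compares with (4-fluorobenzyl)amino on the shared core.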